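The compounds below may be only part of what the source reports. "The series", "measured", "known", "first", "only" and "open" are said of these compounds alone.

Measured so far in an ADME assay on microsomes from liver (Homo sapiens) for metabolic stability (on this read-out higher numbers stand for fast clearance and lower numbers for slow clearance), as follows
- compound 1 `C[C@@H]1CN(c2ccc3c(n2)NC(=O)CO3)[C@H](c2ccccc2F)CO1` gives 14 mL.min-1.g-1
- compound 2 `C[C@@H]1CN(c2ccc3c(n2)NC(=O)CO3)[C@H](c2cccc(F)c2)CO1` gives 9.6 mL.min-1.g-1

Going by the values given here, compound 2 stands within the scatter of compound 1, the only other number available. Compound 3 `C[C@@H]1CN(c2ccc3c(n2)NC(=O)CO3)[C@H](c2ccc(F)cc2)CO1` comes next, with this change from compound 2: 4-fluorophenyl in place of 3-fluorophenyl on a saturated ring carbon on a saturated ring carbon next to the ring nitrogen. Among the compounds with values here, the one measured step bearing on it is another exchange of fluorophenyl groups on that same carbon, a 1.5-fold lower number from compound 1 to compound 2 (0.16 log units; within the scatter) and so no step beyond the scatter is expected in this assay here. The expected step is a 1.0-fold higher number from compound 2 to compound 3 (0.02 log units; within the scatter) on this estimate. For compound 3 the estimated value is 10 mL.min-1.g-1 with an expected range from 5 mL.min-1.g-1 to 20 mL.min-1.g-1 in this series.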

Compound 3, intrinsic clearance in microsomes in the liver assay: 8 mL.min-1.g-1
For compound 3 the middle estimate is 1.3-fold (0.10 log units) above the measured one, and the stated range covers the measured number.
By their numbers in the liver assay, from the lowest: compounds 3, 2 and 1 (each within the scatter of the next).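

In the liver assay compound 1 gives 14 mL.min-1.g-1 and compound 2 gives 9.6 mL.min-1.g-1 and compound 3 gives 8 mL.min-1.g-1; the step of a 1.2-fold lower number from compound 2 to compound 3 (0.08 log units; within the scatter) and the step of a 1.8-fold lower number from compound 1 to compound 3 (0.24 log units; within the scatter) both stay within the scatter, so the 2-fluorophenyl, 3-fluorophenyl and 4-fluorophenyl groups are not separated on this saturated ring carbon. In a physicochemical assay for lipophilicity (on this read-out higher numbers stand for higher lipophilicity and lower numbers for lower lipophilicity), compound 2 gives 3.1 and compound 3 gives 3.2; the exchange gives a number 0.10 log units higher from compound 2 to compound 3 (within the scatter) and separates nothing either. No measurement at hand bears on a cause for this.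

Still open, going by these compounds, is whether a group other than fluorophenyl on this carbon, such as unsubstituted phenyl, a pyridine ring or a chain carrying an amine, moves the number in the liver assay beyond the scatter.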